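Methyl for fluoro: the step from compound 3 to compound 4

The source may report more compounds than this note shows. Statements on the series, on what has been measured and on what is new or still open speak of the compounds shown alone.

compound 1 `Cc1ccc(C2CC(c3ccc(F)cc3)=NN2C(=O)COc2ccc(/C=C3/SC(=O)NC3=O)cc2)cc1` — > 50000 nM in an assay on cells for inhibition of histone deacetylase 8 (Homo sapiens), read by fluorescence, with a stated time of 30 min (a lower number here means a stronger inhibitor, a higher number a weaker inhibitor), a limit
compound 2 `O=C1NC(=O)/C(=C\c2ccc(OCC(=O)N3N=C(c4ccc(F)cc4F)CC3c3ccco3)cc2)S1` — > 50000 nM in this assay, a limit
compound 3 `O=C1NC(=O)/C(=C\c2ccc(OCC(=O)N3N=C(c4ccc(F)cc4F)CC3c3ccc(F)cc3)cc2)S1` — > 50000 nM in this assay, a limit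

All three measured compounds sit at the same limit of this assay, and compound 3 stands there with no number of its own; the two other values shown are limits as well (the limit of > 50000 nM in this assay, at which 3 of the 3 values shown sit). Among the measured compounds shown here, the one measured step, a step that the two limits leave unreadable from compound 2 to compound 3, is unreadable, since both ends are limits. Compound 4 `Cc1ccc(C2CC(c3ccc(F)cc3F)=NN2C(=O)COc2ccc(/C=C3/SC(=O)NC3=O)cc2)cc1` differs from compound 3 by methyl in place of fluoro on an aromatic carbon. For the measured compounds named here, no measured step bears on this change, so nothing points to a reading beyond the limit. Compound 4 is expected at 60000 nM, range 15000 nM to 300000 nM, an expected step that the limit leaves unreadable from compound 3 to compound 4.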

Compound 4, half-maximal inhibitory concentration: > 50000 nM
Compound 4: only a limit was reported (the forecaster's own chance of this, stated with the estimate: 85%); the middle value is on the limit's open side.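

Among the compounds shown here, no step from compound 1, compound 2 or compound 3 to compound 4 can be read, since each end is a limit: the limit of > 50000 nM in this assay, at which 4 of the 4 values shown sit. The compounds shown leave open whether any change to the shared core gives a measurable value in this assay.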